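The source may hold more compounds than are shown below. What is called first, only, known or untested is meant among the compounds shown, and "the series" means these compounds.

Going by the values given here, compound 1 `COc1ccc(-c2[nH]c3ccccc3c2/C=C(\C#N)S(=O)(=O)c2ccccc2)cc1` is one of two compounds measured here in a functional assay on EKVX cells (Homo sapiens) for inhibition, read by sulforhodamine B assay, with a stated time of 48 h; a lower number here means a stronger inhibitor of growth, a higher number a weaker inhibitor of growth. In this assay compound 1 gives 1300 nM, which is the lower of the two numbers. Compound 2 `COc1ccc2[nH]c(-c3ccccc3)c(C=C(C#N)C#N)c2c1` differs from compound 1 in several places at once. In this assay compound 2 gives 4100 nM, a number that lies beyond the usual scatter above that of compound 1. The two structures differ in several places, so no single change can be tied to that gap.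

The next compound, compound 3 `COc1ccc(-c2[nH]c3ccc(OC)cc3c2/C=C(\C#N)S(=O)(=O)c2ccccc2)cc1`, differs from compound 1 in one place only: methoxy in place of hydrogen on an aromatic carbon. Among the compounds with values here, no measured pair shows the effect of this exact change, so the expectation rests on the shared core alone, and a methoxy group on a comparable ring is present in compound 2 without telling what it does by itself. A step of modest size in either direction, or none beyond the scatter, is therefore expected as a 1.2-fold higher number from compound 1 to compound 3 (0.06 log units; within the scatter). For compound 3 the expected result in this assay is 1500 nM, with a plausible range from 500 nM to 4500 nM.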

Compound 3, concentration for 50% growth inhibition: 3300 nM
Compound 3: middle estimate off by 2.2-fold (0.34 log units), on the low side; the measured number falls inside the stated range.
By their numbers in this assay, from the lowest: compound 1; then compounds 3 and 2 (each within the scatter of the next).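

In this assay, going by these compounds alone, methoxy in place of hydrogen on this aromatic carbon gives a 2.5-fold higher number from compound 1 to compound 3 (0.40 log units; beyond the scatter), the first change in one place only that can be read here. The step is modest but lies beyond the usual scatter, so the group has a measurable cost in growth inhibition at this position of the shared core, though compound 3 still gives a finite number of 3300 nM in the same assay. Nothing measured here explains why the number rises with this change.

The compounds shown leave open whether the rise belongs to methoxy specifically or would also appear with another group on this carbon, such as a hydroxyl, a fluorine atom, an amine or a longer ethoxy chain. They also leave open whether the same step would appear on a different core, and what the methoxy group that compound 1 already carries elsewhere contributes by itself.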